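Halogen-to-methyl exchange on the anilino ring of compound 1

The source may hold more compounds than are shown below. What is called first, only, known or untested is meant among the compounds shown, and "the series" means these compounds.

For the measured compounds named here, compound 1 `Fc1cccc(-c2nc(Nc3ccc(Cl)cc3)c3cc(F)ccc3n2)c1` is the only member of this small set that returns a number in a functional assay on HT29-AK cells (Homo sapiens) for cytotoxicity, read by MTT assay, with a stated time of 48 h; a lower number here means a stronger inhibitor, a higher number a weaker inhibitor: compound 1 gives 40300 nM. Compound 2 `Fc1cccc(-c2nc(Nc3cccc(Br)c3)c3cc(F)ccc3n2)c1` sits at a limit of the assay, > 50000 nM. Compound 3 `Fc1cccc(-c2nc(Nc3ccccc3Br)c3cc(F)ccc3n2)c1` likewise sits at a limit, > 50000 nM. Compound 4 `Cc1ccc(Nc2nc(-c3cccc(F)c3)nc3ccc(F)cc23)cc1` differs from compound 1 by methyl in place of chloro on an aromatic carbon. Going by the values given here, the only measured steps from compound 1 move the halogen around the ring, an at least 1.2-fold higher number from compound 1 to compound 2 (0.09 log units; that floor lies within the scatter) and an at least 1.2-fold higher number from compound 1 to compound 3 (0.09 log units; that floor lies within the scatter), both read against (the limit of > 50000 nM in this assay, at which 2 of the 3 values shown sit), so they bound the change only from below. Among the compounds with values here, no measured step swaps chloro for methyl at the same place, and the direction is not fixed by these data. A step near the scatter is expected, a 1.1-fold higher number from compound 1 to compound 4 (0.05 log units; within the scatter). Compound 4 is estimated at 45000 nM, between 20000 nM and 100000 nM.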

Compound 4, half-maximal inhibitory concentration: > 50000 nM
Compound 4: a limit, no number; the forecaster's own chance of this, stated with the estimate: 45%; at least 1.1-fold (0.04 log units) between middle value and limit.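

Methyl in place of chloro on an aromatic carbon, with the ring position kept, gives an at least 1.2-fold higher number from compound 1 to compound 4 (0.09 log units; that floor lies within the scatter) in this assay; this is a floor and not a size. For the compounds shown here, compound 1 is still the only compound with a number, and the change at this position leaves compound 4 at a limit as well: the limit of > 50000 nM in this assay, at which 3 of the 4 values shown sit. The steps from compound 2 and from compound 3 to compound 4 cannot be read.

Going by these compounds, whether an amine or a carboxylic acid at this position would return a number in this assay stays open. On these data alone, the true size of the chloro-to-methyl step also stays open.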